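This account rests on a few compounds, and the source may have more. Where it says the series, first, only, none or still open, it means among the compounds named here.

Measured compounds:
compound 1, `C/C=C/C=C/C(=O)N[C@H](C(=O)NCCCCCCCCCCCC)[C@@H](C)O`, 37100 nM
compound 2, `CCCCCCCCCCCCNC(=O)[C@@H](NS(=O)(=O)c1ccc(C)cc1)[C@@H](C)O`, 31100 nM
compound 3, `C/C=C/C=C/C(=O)N[C@H](C(=O)NCCCCCCCCCCCCCCCCCC)[C@@H](C)O`, 79600 nM

Of the compounds shown here, three have been read in a functional assay on MCF7 cells (Homo sapiens) for cytotoxicity, read by MTT assay, with a stated time of 48 h; a higher number here means a weaker inhibitor, a lower number a stronger inhibitor; compound 4, `CCCCCCCCCCCCCCCCCCNC(=O)[C@@H](NS(=O)(=O)c1ccc(C)cc1)[C@@H](C)O`, has not. Compound 2 is obtained from compound 1 by (4-methylphenyl)sulfonyl in place of (penta-1,3-dien-1-yl)carbonyl on an amine nitrogen. In this assay that change gave a 1.2-fold lower number from compound 1 to compound 2 (0.08 log units; within the scatter). Compound 3 differs from compound 1 in its core: hexyl in place of hydrogen on a saturated chain carbon, ten or more bonds along the chain from an amide-type nitrogen, and in this assay this gave a 2.1-fold higher number from compound 1 to compound 3 (0.33 log units; beyond the scatter), so compound 3 sits at the high end of the three numbers.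

Compound 4 is made from compound 3 by (4-methylphenyl)sulfonyl in place of (penta-1,3-dien-1-yl)carbonyl on an amine nitrogen, the same change as from compound 1 to compound 2, placed on the core of compound 3. Going by the values given here, only the one earlier example of this change is available, and it lay within the scatter. The expectation is therefore that compound 4 keeps close to compound 3, with an estimated step of a 1.2-fold lower number from compound 3 to compound 4 (0.07 log units; within the scatter), resting on a 1.2-fold lower number from compound 1 to compound 2 (0.08 log units; within the scatter). In this assay compound 4 is thus estimated at 68000 nM, expected between 30000 nM and 150000 nM, with some chance that at this weak level only a limit is returned.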

Compound 4, half-maximal inhibitory concentration: 60100 nM
Compound 4: the middle estimate sits 1.1-fold (0.05 log units) above what was measured, and the stated range covers the measured number.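

In this assay, placing (4-methylphenyl)sulfonyl on the amine nitrogen of the core of compound 3 in place of (penta-1,3-dien-1-yl)carbonyl gives a 1.3-fold lower number from compound 3 to compound 4 (0.12 log units; within the scatter), and this step agrees with the earlier one: the same change on two cores in this assay, a 1.2-fold lower number (0.08 log units; within the scatter) from compound 1 to compound 2 and a 1.3-fold lower number (0.12 log units; within the scatter) from compound 3 to compound 4, 1.1-fold (0.05 log units) apart, within the scatter of two such steps

The hexyl change, read on the sulfonyl side of the series, gives a 1.9-fold higher number from compound 2 to compound 4 (0.29 log units; within the scatter), and it also carries over: the same change on two cores in this assay, a 2.1-fold higher number (0.33 log units; beyond the scatter) from compound 1 to compound 3 and a 1.9-fold higher number (0.29 log units; within the scatter) from compound 2 to compound 4, 1.1-fold (0.05 log units) apart, within the scatter of two such steps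

So within these four compounds the two changes combine without a visible interaction, but the sulfonyl swap is a step within the scatter on both cores, and this square of compounds shows neither that the swap would stay silent on a different core nor why the steps agree.

Still open, going by these compounds, is whether other groups on the amine nitrogen, such as acetyl or benzoyl, would track the (4-methylphenyl)sulfonyl result. Also open, on these data alone, is whether a shorter chain, or a chain ending in an amine or a carboxylic acid, would continue the hexyl step in this assay.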